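The source may hold more compounds than are shown below. What is called first, only, known or untested is meant among the compounds shown, and "the series" means these compounds.

Compound 1 `CC(O)(COc1cccc(S(F)(F)(F)(F)F)c1)C(=O)Nc1ccc(C(F)(F)F)cc1` is the starting point. In a functional assay on DU-145 cells (Homo sapiens) for antiproliferative activity, read by propidium iodide staining, with a stated time of 96 h (on this read-out lower numbers stand for stronger inhibition and higher numbers for weaker inhibition), compound 1 gives 21000 nM. Compound 3 `CC(O)(COc1cccc(C(F)(F)C(F)(F)F)c1)C(=O)Nc1ccc(C(F)(F)F)cc1` carries one change on the aromatic ring, (a group of 7 heavy atoms (2 carbon, 5 fluorine; no ring) in place of a group of 6 heavy atoms (5 fluorine, 1 sulfur; no ring), on an aromatic carbon), and in this assay compound 3 gives 7600 nM, a step of a 2.8-fold lower number from compound 1 to compound 3 (0.44 log units; beyond the scatter).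

Compound 2 `CC(O)(COc1cccc(S(F)(F)(F)(F)F)c1)C(=O)Nc1cc(C(F)(F)F)cc(C(F)(F)F)c1` is built on a different core; how its core differs from that of compound 1 is not broken down here. In this assay compound 2 gives 5700 nM.

Compound 4 `CC(O)(COc1cccc(C(F)(F)C(F)(F)F)c1)C(=O)Nc1cc(C(F)(F)F)cc(C(F)(F)F)c1` is not yet measured. It stands to compound 2 as compound 3 stands to compound 1, with the same change at the same place: a group of 7 heavy atoms (2 carbon, 5 fluorine; no ring) in place of a group of 6 heavy atoms (5 fluorine, 1 sulfur; no ring), on an aromatic carbon. The step is expected to be a 2.5-fold lower number from compound 2 to compound 4 (0.39 log units; beyond the scatter), resting on the step already seen in a 2.8-fold lower number from compound 1 to compound 3 (0.44 log units; beyond the scatter). For compound 4 in this assay the expected value is therefore 2300 nM, estimated to lie between 1000 nM and 5500 nM.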

Compound 4, half-maximal inhibitory concentration: 8500 nM
Compound 4: the middle estimate sits 3.7-fold (0.57 log units) below what was measured; measured number outside the range, above it.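

In this assay, placing 1,1,2,2,2-pentafluoroethyl where the sulfur group with its five fluorine atoms stood gives a 1.5-fold higher number from compound 2 to compound 4 (0.17 log units; within the scatter) and so, on this core, no difference that can be told from scatter. The change therefore did not carry over unchanged from one core to the other: the same change on two cores in this assay, a 2.8-fold lower number (0.44 log units; beyond the scatter) from compound 1 to compound 3 and a 1.5-fold higher number (0.17 log units; within the scatter) from compound 2 to compound 4, 4.1-fold (0.61 log units) apart, beyond the scatter of two such steps. Among the compounds shown here, this shows that a step seen on one core cannot simply be assumed on another, but with only two cores it does not show why the steps differ or what the change would do on a third core.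

Still open, going by these compounds, is how a chlorine atom, a nitrile or a longer fluorinated chain in the same place would behave on these two cores.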